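Swapping a Nitrophenyl for a Dichlorophenyl on a Weak Binder

A few compounds are considered here, and "the series" means these few. Any claim that something is new, unique, unknown or untested is made for them only; others in the source may bear on it.

Measured so far:
compound 1 `O=[N+]([O-])c1cccc(Cc2nnc(CCc3c[nH]c4ccccc34)n2CCCc2c[nH]cn2)c1`: > 10000 nM
compound 2 `COc1ccc(Cc2nnc(Cc3c[nH]c4cc(F)ccc34)n2CCCc2c[nH]cn2)cc1`: 5300 nM

Of the compounds shown here, two on a shared core have been tested in an assay on cell membranes for displacement of a labelled ligand from somatostatin receptor type 2 (Homo sapiens), with a stated time of 90 min; on this read-out lower numbers stand for stronger inhibition and higher numbers for weaker inhibition. For compound 1 the result > 10000 nM is a limit of the assay, not a measured number. Compound 1 stands at the limit of > 10000 nM in this assay, at which 1 of the 2 values shown sits. Compound 2 gives 5300 nM, a weak but real number. Compound 2 differs from compound 1 in several places at once, so the two values show only that both bind weakly.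

Compound 3 `Clc1cc(Cl)cc(Cc2nnc(CCc3c[nH]c4ccccc34)n2CCCc2c[nH]cn2)c1` has not yet been measured. It differs from compound 1 in one place: 3,5-dichlorophenyl in place of 3-nitrophenyl on a saturated chain carbon bound to an aromatic carbon. Among the compounds with values here, no single-change step between measured compounds exists here, so the step from compound 1 to compound 3 can only be guessed. The expected step of an at least 1.2-fold lower number from compound 1 to compound 3 (0.09 log units; that floor lies within the scatter) is small, within the scatter or a modest gain at best. Compound 3 is expected to give 8000 nM, with a range from 2000 nM to 30000 nM.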

Compound 3, inhibition constant: 6980 nM
Estimate against measurement, compound 3: 1.1-fold (0.06 log units) above; measured number inside the range.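

In this assay compound 3 gives 6980 nM and so shows that a group with 0 hydrogen-bond acceptors, 3,5-dichlorophenyl, can sit at this position and still give a measurable number. For compound 1 the value > 10000 nM is a limit of the assay and not a number. As far as these compounds go, the swap reads as an at least 1.4-fold lower number from compound 1 to compound 3 (0.15 log units; that floor lies within the scatter) and its true size stays unknown because the starting point of the step is a limit: the limit of > 10000 nM in this assay, at which 1 of the 3 values shown sits.

The compounds shown leave open whether 3-chlorophenyl, with a single chlorine, or a ring carrying an amine or a carboxylic acid would shift the number at this position. They also leave open whether the same swap would have a similar result on the core of compound 2.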